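Difluorophenyl Swap on a Second Core: Cytotoxicity Outlook

A few compounds are considered here, and "the series" means these few. Any claim that something is new, unique, unknown or untested is made for them only; others in the source may bear on it.

Three compounds were profiled in an ADME assay on MT4 cells (Homo sapiens) for cytotoxicity, read by MTT assay, with a stated time of 5 days; a lower number here means that less compound is tolerated, a higher number that more compound is tolerated. Compound 1 `Cc1cc(C)cc(S(=O)(=O)Nc2ccnc(Nc3ccc(C#N)cc3)c2)c1` carries a 3,5-dimethylphenyl on its sulfonyl sulfur, and in this assay compound 1 gives 5060 nM. Compound 2 `N#Cc1ccc(Nc2cc(NS(=O)(=O)c3cc(F)cc(F)c3)ccn2)cc1` differs from it only in one place: 3,5-difluorophenyl in place of 3,5-dimethylphenyl on a sulfonyl sulfur. That change produced a 5.7-fold higher number from compound 1 to compound 2 (0.75 log units; beyond the scatter), so more of compound 2 is tolerated than of compound 1.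

Compound 3 `Cc1cc(C)cc(S(=O)(=O)Nc2ccnc(Nc3ccc(C#N)cc3)n2)c1` keeps the 3,5-dimethylphenyl of compound 1 but sits on a different core; the difference between the two cores is not broken down here. Compound 3 stands highest of the three in this assay, where compound 3 gives 173000 nM, compared with compound 2 at 28600 nM and compound 1 at 5060 nM.

Compound 4 `N#Cc1ccc(Nc2nccc(NS(=O)(=O)c3cc(F)cc(F)c3)n2)cc1` has not yet been measured. It relates to compound 3 exactly as compound 2 relates to compound 1: 3,5-difluorophenyl in place of 3,5-dimethylphenyl on a sulfonyl sulfur. The place of the change is the same in both pairs, a sulfonyl sulfur whose other neighbour is the sulfonamide nitrogen, so this is the same change seen once before. On the evidence of that single earlier step, compound 1 to compound 2 at a 5.7-fold higher number from compound 1 to compound 2 (0.75 log units; beyond the scatter), the author expects a step of roughly a 3.5-fold higher number from compound 3 to compound 4 (0.54 log units; beyond the scatter) in this assay from compound 3 to compound 4, with the caveat that the change has been observed only once and on another core. Compound 4 is therefore estimated at 600000 nM in this assay, within a range of 180000 nM to 2000000 nM.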

Compound 4, half-maximal cytotoxic concentration: 93900 nM
For compound 4 the middle estimate is 6.4-fold (0.81 log units) above the measured one; measured number outside the range, below it.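

In this assay, the same exchange on the second core gave a 1.8-fold lower number from compound 3 to compound 4 (0.27 log units; within the scatter), so on this core the step cannot be told apart from repeat measurement. The change therefore did not carry over with its size intact, and the step seen on the core of compound 1 was no reliable guide to the step on the core of compound 3: the same change on two cores in this assay, a 5.7-fold higher number (0.75 log units; beyond the scatter) from compound 1 to compound 2 and a 1.8-fold lower number (0.27 log units; within the scatter) from compound 3 to compound 4, 10-fold (1.02 log units) apart, beyond the scatter of two such steps. This shows that, in these two pairs, the outcome of placing 3,5-difluorophenyl on the sulfonyl sulfur differs with the core, but it does not show a true reversal of direction, since the second step lies within the scatter, and two pairs cannot reveal which feature of the cores is responsible or what a third core would do.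

The compounds shown leave open how other groups on the sulfonyl sulfur, such as a 3,5-dichlorophenyl or a phenyl carrying an amine, would behave on these two cores. They also leave open whether the difference between the two cores would persist if the nitrile on the other ring gave way to a carboxylic acid or a longer chain.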